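Extending the chain of a sulfonylurea chalcone toward brine shrimp

The source may report more compounds than this note shows. Statements on the series, on what has been measured and on what is new or still open speak of the compounds shown alone.

Compounds measured so far in an ADME assay on the whole organism for cytotoxicity, with Artemia salina as the target, with a stated time of 24 h; on this read-out lower numbers stand for an effect already at smaller amounts and higher numbers for an effect only at larger amounts of compound:
compound 1, `Cc1ccc(S(=O)(=O)NC(=O)Nc2ccccc2C(=O)/C=C/c2cccc([N+](=O)[O-])c2)cc1`: 44.5 ug/mL
compound 2, `Cc1ccc(S(=O)(=O)NC(=O)Nc2ccccc2C(=O)/C=C/c2ccc(Cl)cc2)cc1`: 6.92 ug/mL

Compound 2 stands at the lowest of the two numbers recorded in this assay; its nearest neighbour is compound 1, and the step of a 6.4-fold lower number from compound 1 to compound 2 (0.81 log units; beyond the scatter) lies beyond the scatter. Compound 3, `Cc1ccc(S(=O)(=O)NC(=O)Nc2ccccc2C(=O)/C=C/C=C/c2ccccc2)cc1`, has not yet been measured. It differs from compound 2 in one place: 2-phenylethenyl in place of 4-chlorophenyl on a double-bonded chain carbon bound to a double-bonded chain carbon.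

Among the compounds with values here, only one measured step is available, and it concerns a different exchange on the same chain carbon, the replacement of a 3-nitrophenyl by a 4-chlorophenyl; it was modest in size and lowered the number. Within the data shown here, no measured pair shows what lengthening the chain by a 2-phenylethenyl unit does in this assay, so that step gives only weak guidance here. The expectation for compound 3 is therefore a number close to that of compound 2, with a step of a 1.7-fold higher number from compound 2 to compound 3 (0.24 log units; within the scatter) that is not expected to go clearly beyond the scatter in either direction. Compound 3 is estimated at 12 ug/mL in this assay, within a range from 4 ug/mL to 40 ug/mL.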

Compound 3, concentration for half-maximal effect: 18.2 ug/mL
The estimate for compound 3 lay 1.5-fold (0.18 log units) below the measured number; measured number inside the range.
By their numbers in this assay, from the lowest: compound 2; then compound 3; then compound 1.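

In this assay, the place on a double-bonded chain carbon bound to a double-bonded chain carbon now carries three different groups, and the three compounds are separated by steps beyond the scatter. Putting 2-phenylethenyl in place of 4-chlorophenyl gives a 2.6-fold higher number from compound 2 to compound 3 (0.42 log units; beyond the scatter) and putting it in place of 3-nitrophenyl gives a 2.4-fold lower number from compound 1 to compound 3 (0.39 log units; beyond the scatter) so the group with the added double bond outside the aromatic ring falls between the two groups measured earlier, not outside their span. No measurement at hand accounts for this order.

Compound 3 carries no chlorine and has a longer chain than compound 2, so the step combines two differences, and the compounds shown cannot separate the contribution of the chain from that of the chlorine. A 4-(4-chlorophenyl)buta-1,3-dien-1-yl group would bear on that question, while a still longer chain such as 6-phenylhexa-1,3,5-trien-1-yl would show whether the number keeps moving as the chain grows.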